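The source may hold more compounds than are shown below. What is called first, only, known or untested is meant among the compounds shown, and "the series" means these compounds.

Measured compounds:
- compound 1, `C/C(=N\N=C1/SCC(=O)N1Cc1cccc(F)c1)c1cccs1`, gives 6 ug/mL in an ADME assay on HEp-2 cells (Homo sapiens) for cytotoxicity, read by trypan blue exclusion, with a stated time of 24 h; a higher number here means that more compound is tolerated, a lower number that less compound is tolerated
- compound 2, `C/C(=N/N=C1\SCC(=O)N1Cc1ccc(F)cc1)c1ccccn1`, gives 16 ug/mL in this assay

Compound 1 stands at the lower of the two numbers measured in this assay, so the cells tolerate less of it than of compound 2, and the gap between the two lies beyond the usual scatter of this kind of measurement.

The step considered here leads from compound 1 to compound 3, `C/C(=N\N=C1/SCC(=O)N1Cc1ccccc1F)c1cccs1`, which has not yet been measured in this assay. The two molecules contain the same atoms, joined differently: 2-fluorophenyl in place of 3-fluorophenyl on a saturated chain carbon bound to an amide-type nitrogen in a ring. The fluorine thus stays on the same ring and only its position on that ring is changed, with nothing else in the molecule touched.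

Within the data shown here, no measured pair of compounds shows what such a move of a fluorine does in this assay. Among the measured compounds shown here, with only two measured numbers, neither of which involves this change, the expectation is that compound 3 stays close to compound 1, with the step of a 1.2-fold higher number from compound 1 to compound 3 (0.07 log units; within the scatter) expected to be small and within the scatter. Compound 3 is therefore estimated at 7 ug/mL, within a range from 3 ug/mL to 16 ug/mL.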

Compound 3, half-maximal cytotoxic concentration in the HEp-2 assay: 15 ug/mL
Estimate against measurement, compound 3: 2.1-fold (0.33 log units) below, and the stated range covers the measured number.
By their numbers in the HEp-2 assay, from the lowest: compound 1; then compounds 3 and 2 (each within the scatter of the next).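

In the HEp-2 assay, the swap of 3-fluorophenyl for 2-fluorophenyl gives a 2.5-fold higher number from compound 1 to compound 3 (0.40 log units; beyond the scatter), the first measured sign that moving a fluorine around the same ring, with the atoms unchanged, can by itself alter how much compound the cells tolerate. No such shift appears in a physicochemical assay, with a stated time of 30 min (on this read-out higher numbers stand for weaker inhibition and lower numbers for stronger inhibition), where compound 1 gives 21100000 nM and compound 3 gives 15700000 nM, two numbers within the usual scatter of each other, so this read-out does not separate the two compounds. Nothing available explains why the fluorine's position matters in one read-out and not in the other.

Among these compounds, this is a single pair, so it sets no rule for other compounds, and compound 2 differs from both compounds in more than one place and cannot help to extend it. Going by these compounds, it remains open how the core of compound 1 would behave with a plain phenyl group or a 2-chlorophenyl group on that saturated chain carbon bound to an amide-type nitrogen in a ring.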